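Moving a Methyl Group Around a Phenyl Ring

This account rests on a few compounds, and the source may have more. Where it says the series, first, only, none or still open, it means among the compounds named here.

Compound 1, `COc1cc2ncnc(NNC(=S)NC(=O)c3ccccc3C)c2cc1OC`, gives 10500 nM in a functional assay on CNE-2 cells (Homo sapiens) for cytotoxicity, read by MTT assay, with a stated time of 72 h; a higher number here means a weaker inhibitor, a lower number a stronger inhibitor.
Compound 2, `O=C(NC(=S)NNc1ncnc2ccccc12)c1cccc(Cl)c1`, gives 2920 nM.
Compound 3, `O=C(NC(=S)NNc1ncnc2ccccc12)c1ccc(Cl)cc1`, gives 1530 nM.

Compound 1 stands highest of the three numbers, beyond the scatter from both compound 2 and compound 3. Compound 4, `COc1cc2ncnc(NNC(=S)NC(=O)c3ccc(C)cc3)c2cc1OC`, is built from the same atoms as compound 1, joined differently: 4-methylphenyl in place of 2-methylphenyl on a carbonyl carbon. Among the measured compounds shown here, the only measured step that bears on this is a 1.9-fold lower number from compound 2 to compound 3 (0.28 log units; within the scatter), which also exchanged one substituted phenyl for another on a carbonyl carbon and stayed within the scatter. A small step in this assay, at most slightly downward, is therefore expected: a 1.5-fold lower number from compound 1 to compound 4 (0.18 log units; within the scatter). Compound 4 is estimated at 7000 nM, with a range from 3000 nM to 18000 nM.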

Compound 4, half-maximal inhibitory concentration: 33300 nM
Beside the measured number, compound 4's estimate is 4.8-fold (0.68 log units) below it; the measured number lies above the stated range.
By their numbers in this assay, from the lowest: compounds 3 and 2 (each within the scatter of the next); then compound 1; then compound 4.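

Exchanging 2-methylphenyl for 4-methylphenyl on a carbonyl carbon gives a 3.2-fold higher number from compound 1 to compound 4 (0.50 log units; beyond the scatter) in this assay and makes compound 4 the weaker inhibitor. Among the compounds shown here, the earlier step between the two chlorophenyl compounds stayed within the scatter, so this is the first change at this position that clearly exceeds it, even with the same atoms in both compounds. Nothing available explains why the number rises.

The compounds shown leave open how this position would respond to an amine, a carboxylic acid or a longer chain such as propyl on the phenyl ring. They also leave open whether the 4-methylphenyl result would hold on another core.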